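The source may report more compounds than this note shows. Statements on the series, on what has been measured and on what is new or still open speak of the compounds shown alone.

Compound 2 `O=C(C1CCCCO1)N1CCc2nc(C#Cc3ccccc3)sc2C1` stands at the edge of what the numbers can show: in an assay on HEK293 cells for negative allosteric modulation of metabotropic glutamate receptor 5 (Homo sapiens), read by FLIPR, with a stated time of 1 h (on this read-out higher numbers stand for weaker inhibition and lower numbers for stronger inhibition), compound 2 gives > 10000 nM, which is a limit of the assay rather than a measured number, as the limit of > 10000 nM in this assay, at which 1 of the 2 values shown sits, records. Going by the values given here, compound 1 `CC(C)CN1CCc2nc(C#Cc3ccccc3)sc2C1` is the only other measured compound; in this assay compound 1 gives 650 nM. Among the compounds with values here, the single measured step that bears on the present question is an at least 15-fold higher number from compound 1 to compound 2 (1.18 log units; beyond the scatter), where the isobutyl on the ring amine nitrogen gave way to an acyl group. Compound 3 `O=S(=O)(C1CC1)N1CCc2nc(C#Cc3ccccc3)sc2C1` differs from compound 2 in one place: cyclopropylsulfonyl in place of (oxan-2-yl)carbonyl on an amine nitrogen in a ring. The change keeps a non-basic substituent with two hydrogen-bond acceptors on that nitrogen, so the large loss seen in the measured step offers no ground for expecting a return toward compound 1. Compound 3 is therefore expected to remain at or near the limit, with an expected step that the limit leaves unreadable from compound 2 to compound 3 and an estimate of 15000 nM, ranging from 3000 nM to 50000 nM.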

Compound 3, half-maximal inhibitory concentration: 34 nM
For compound 3 the middle estimate is 440-fold (2.64 log units) above the measured one; the whole stated range lies above it.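

At this position on the ring amine nitrogen, replacing isobutyl does not in itself cost activity: in this assay, the cyclopropylsulfonyl group gives a 19-fold lower number from compound 1 to compound 3 (1.28 log units; beyond the scatter), whereas the acyl group had moved the number the other way. The choice of group on this nitrogen therefore decides the outcome in both directions, with an at least 290-fold lower number from compound 2 to compound 3 (2.46 log units; beyond the scatter), although (oxan-2-yl)carbonyl and cyclopropylsulfonyl match in their counts of hydrogen-bond donors and acceptors and neither carries a net charge, so those counts do not separate them. The value of compound 2 is a limit and not a number, so this step has no upper bound: the limit of > 10000 nM in this assay, at which 1 of the 3 values shown sits.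

Going by these compounds, the change swaps the carbonyl for a sulfonyl and the oxane ring for a cyclopropyl ring at once, so the share of each remains open. A cyclopropylcarbonyl or a methylsulfonyl group on the same nitrogen would separate the two.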